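A few compounds are considered here, and "the series" means these few. Any claim that something is new, unique, unknown or untested is made for them only; others in the source may bear on it.

Measured in a functional assay on A549 cells (Homo sapiens) for cytotoxicity, read by MTT assay, with a stated time of 72 h; a lower number here means a stronger inhibitor, a higher number a weaker inhibitor:
- compound 1 `O=C(/C=C/c1ccc([N+](=O)[O-])cc1)Nc1cc2c(Nc3ccc(F)c(Cl)c3)ncnc2cc1O[C@H]1CCOC1`: 12000 nM
- compound 2 `COc1ccc(/C=C/C(=O)Nc2cc3c(Nc4ccc(F)c(Cl)c4)ncnc3cc2O[C@H]2CCOC2)c(OC)c1`: 9350 nM
- compound 3 `COc1cc(/C=C/C(=O)Nc2cc3c(Nc4ccc(F)c(Cl)c4)ncnc3cc2O[C@H]2CCOC2)cc(OC)c1`: 10800 nM

On these numbers, compound 3 cannot be told apart from the other two, since its steps to them stay within the usual scatter: a 1.1-fold lower number from compound 1 to compound 3 (0.05 log units; within the scatter) and a 1.2-fold higher number from compound 2 to compound 3 (0.06 log units; within the scatter). The next molecule, compound 4 `O=C(/C=C/c1ccc(F)cc1Cl)Nc1cc2c(Nc3ccc(F)c(Cl)c3)ncnc2cc1O[C@H]1CCOC1`, carries 2-chloro-4-fluorophenyl in place of 3,5-dimethoxyphenyl on a double-bonded chain carbon bound to a double-bonded chain carbon.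

The three measured steps all changed the group at this same place, and the remaining one, a 1.3-fold lower number from compound 1 to compound 2 (0.11 log units; within the scatter), is also within the scatter. So far, then, swapping this group has left this assay essentially unmoved. Among the compounds with values here, none of the measured compounds has chlorine or fluorine on this ring, so the precedent is imperfect and the range is kept wide. No shift beyond the scatter is expected, and the estimated change is a 1.1-fold lower number from compound 3 to compound 4 (0.06 log units; within the scatter). For compound 4 the estimated value is 9500 nM, with an expected range of 4500 nM to 18000 nM.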

Compound 4, half-maximal inhibitory concentration: 5190 nM
Beside the measured number, compound 4's estimate is 1.8-fold (0.26 log units) above it; the range from low to high includes it.
By their numbers in this assay, from the lowest: compounds 4, 2, 3 and 1 (each within the scatter of the next, the first and the last beyond it).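

In this assay the group at this place can, after all, shift the number slightly: a 2.1-fold lower number from compound 3 to compound 4 (0.32 log units; beyond the scatter) and a 2.3-fold lower number from compound 1 to compound 4 (0.36 log units; beyond the scatter) are both modest but beyond the scatter, while a 1.8-fold lower number from compound 2 to compound 4 (0.26 log units; within the scatter) stays within it. Within the data shown here, the swaps among the earlier groups left the number unmoved, so 2-chloro-4-fluorophenyl is the first group here that separates from any other, yet it separates from only two of the three and cannot be told apart from the 2,4-dimethoxyphenyl of compound 2. Nothing available explains this shift.

The chlorine and the fluorine enter together, so the compounds shown leave open which of them, if either, accounts for the change. From the compounds shown here alone, how a phenyl ring carrying only chlorine, only fluorine, an amine or a carboxylic acid would behave at this place also remains open.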